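A few compounds are considered here, and "the series" means these few. Any claim that something is new, unique, unknown or untested is made for them only; others in the source may bear on it.

Among the compounds with values here, in a functional assay on PC-3 cells (Homo sapiens) for antiproliferative activity, read by MTT assay, with a stated time of 48 h (a higher number here means a weaker inhibitor, a lower number a stronger inhibitor), compound 2 `O=C(Nc1cc(Sc2ncn[nH]2)c(O)c2ccccc12)c1ccc([N+](=O)[O-])cc1` is the only compound that gives a number, namely 53500 nM. Compound 1 `O=C(/C=C/c1ccc([N+](=O)[O-])cc1)Nc1cc(Sc2ncn[nH]2)c(O)c2ccccc12` is reported in this assay only as a limit, > 100000 nM, which places it at the limit of > 100000 nM in this assay, at which 1 of the 2 values shown sits. Compound 3 `O=C(Nc1cc(Sc2ncn[nH]2)c(O)c2ccccc12)c1cccc([N+](=O)[O-])c1` has not yet been tested; it differs from compound 2 by 3-nitrophenyl in place of 4-nitrophenyl on a carbonyl carbon. Within the data shown here, with no measured pair of this kind to lean on, the change is expected to stay within the usual scatter, with no clear direction, and is estimated as a 1.0-fold higher number from compound 2 to compound 3 (0.01 log units; within the scatter). Compound 3 is therefore expected to give about 55000 nM, within 20000 nM to 150000 nM.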

Compound 3, half-maximal inhibitory concentration: 26900 nM
For compound 3 the middle estimate is 2.0-fold (0.31 log units) above the measured one, and the stated range covers the measured number.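

In this assay, within the data shown here, 3-nitrophenyl in place of 4-nitrophenyl on a carbonyl carbon gives the first step that can be read, a 2.0-fold lower number from compound 2 to compound 3 (0.30 log units; within the scatter), so the two nitrophenyl groups are not told apart at this place. Compound 1 remains a limit rather than a number, and steps to it cannot be read: the limit of > 100000 nM in this assay, at which 1 of the 3 values shown sits.

On these data alone, whether an amine or a carboxylic acid in place of the nitro group on this phenyl ring would shift the number beyond the scatter stays open. So does the effect of a plain phenyl at this place.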